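This account rests on a few compounds, and the source may have more. Where it says the series, first, only, none or still open, it means among the compounds named here.

Measured in an ADME assay on MT4 cells (Homo sapiens) for cytotoxicity, read by MTT assay, with a stated time of 96 h; a higher number here means that more compound is tolerated, a lower number that less compound is tolerated:

- compound 1 `Fc1ccc(F)c(/N=N/c2ccc(NC[C@@H]3CCCN4CCCC[C@H]34)c3c2CCCC3)c1`: 40000 nM
- compound 2 `c1ccc(/N=N/N2CCN(c3ccccc3)CC2)cc1`: 33000 nM
- compound 3 `CN(C)CCCN(/N=N/c1c(F)cccc1F)c1ccccc1`: 23000 nM

These three structures look very different, yet their numbers sit close together. Compound 2, at 33000 nM, cannot be told apart from compound 1 or compound 3, since its value lies within the usual scatter of both.

Compound 4 `c1ccc(/N=N/N2CCN(c3ncccn3)CC2)cc1` has not yet been measured. It carries pyrimidin-2-yl in place of phenyl on an amine nitrogen in a ring.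

Among the measured compounds shown here, no two measured compounds differ in only one place, so the data give no direct guide to this swap. Even compound 1, at 40000 nM, and compound 3, at 23000 nM, stay within the scatter of each other, so a change of one ring is expected to do little in this assay. The expected result is a 1.3-fold higher number from compound 2 to compound 4 (0.10 log units; within the scatter), which is no real step beyond the scatter, with only a slight lean towards a higher number. For compound 4 the estimate is 42000 nM, with an expected range of 18000 nM to 100000 nM.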

Compound 4, half-maximal cytotoxic concentration: 90000 nM
Compound 4: the middle estimate sits 2.1-fold (0.33 log units) below what was measured; the range from low to high includes it.
By their numbers in this assay, from the lowest: compounds 3, 2 and 1 (each within the scatter of the next); then compound 4.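

In this assay, among the compounds shown here, the replacement of phenyl by pyrimidin-2-yl on the amine nitrogen in a ring gives a 2.7-fold higher number from compound 2 to compound 4 (0.44 log units; beyond the scatter) and is the only step in this set that can be read directly. It shows that this position is not indifferent: with the ring still six-membered and aromatic and the heavy-atom count unchanged, exchanging ring carbon for nitrogen is enough to raise the concentration the cells tolerate. No measurement shown here explains this shift.

Going by these compounds, it remains open how a pyridin-2-yl ring, with less ring nitrogen, or a small non-aromatic group such as methyl would behave at this place. On these data alone, whether the same replacement would have a similar effect on a different core, such as that of compound 1, also remains open.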